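This account rests on a few compounds, and the source may have more. Where it says the series, first, only, none or still open, it means among the compounds named here.

Measured so far:
compound 1 `CC1=NN(C(=O)c2cc3ccccc3oc2=O)C(=O)C1CNc1cccc(S(N)(=O)=O)c1` gives 67.8%
compound 2 `CC1=NN(C(=O)c2cc3ccccc3oc2=O)C(=O)C1CNc1ccc(S(N)(=O)=O)cc1` gives 68.9%
compound 3 `CC1=NN(C(=O)c2cc3ccccc3oc2=O)C(=O)C1CNc1ccc(O)c(C(=O)O)c1` gives 30.9%

All three share one core and differ only in the group on the amine nitrogen. In a functional assay on the whole organism for inhibition, with Rattus norvegicus as the target, read by paw edema, with stated times of 1 h and 4 h, at a dose of 0.03 mg/kg by the oral route (a lower number here means less inhibition, a higher number more inhibition at the dose given (going by the name of the read-out)), compound 2 has the highest of the three numbers, but its nearest neighbour is compound 1, and that gap, a number 1.1 percentage points higher from compound 1 to compound 2 (within the scatter), is within the scatter, so the two cannot be ordered. Compound 3 sits far lower: a number 38 percentage points lower from compound 2 to compound 3 (beyond the scatter) and a number 36.9 percentage points lower from compound 1 to compound 3 (beyond the scatter) are both large.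

Compound 4 `CC1=NN(C(=O)c2cc3ccccc3oc2=O)C(=O)C1CNc1ccc(C(=O)O)cc1` has not yet been measured. It is made from compound 2 by the change (carboxy in place of sulfamoyl on an aromatic carbon). Going by the values given here, the one measured step that bears on it is the step from compound 2 to compound 3, where sulfamoyl gave way to a carboxy group together with a hydroxy group and the number fell sharply. Compound 4 carries the carboxy group alone, so a drop is expected, though the size is uncertain; the expected step is a number 26.9 percentage points lower from compound 2 to compound 4 (beyond the scatter). Compound 4 is thus estimated at 42%, with a range from 22% to 62%.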

Compound 4, a percentage reported as inhibition, in the whole organism at one dose (the size of the read-out at that dose, not a potency): 63.6%
Compound 4: the middle estimate sits 21.6 percentage points below what was measured; the measured number lies above the stated range.
By their numbers in this assay, from the lowest: compound 3; then compounds 4, 1 and 2 (each within the scatter of the next).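

In this assay, carboxy can take the place of sulfamoyl on this aromatic carbon, para to a large group, with no readable loss (a number 5.3 percentage points lower from compound 2 to compound 4 (within the scatter)). Compound 4 also cannot be told apart from the isomeric sulfonamide (a number 4.2 percentage points lower from compound 1 to compound 4 (within the scatter)), so a carboxy group alone does not bring the low number of compound 3. The low number goes instead with the whole 3-carboxy-4-hydroxyphenyl group, as the large step to the 4-carboxyphenyl group shows (a number 32.7 percentage points higher from compound 3 to compound 4 (beyond the scatter)).

These compounds cannot separate the hydroxy group from the place of the carboxy group in compound 3, and they do not show whether a nitrile or an amine on this carbon would give a similar number. Nothing available gives a reason for any of these steps.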